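Extending the Saturated Chain of a Trimethoxyanilide by One Carbon

The compounds below may be only part of what the source reports. "The series", "measured", "known", "first", "only" and "open" are said of these compounds alone.

Measured compounds:
compound 1, `CCCCCCCC/C=C/CCCCCCC(C)(C)C(=O)Nc1c(OC)cc(OC)cc1OC`, 44 nM
compound 2, `CCCCCCCCCCCCCC(=O)Nc1c(OC)cc(OC)cc1OC`, 190 nM
compound 3, `CCCCCCCCCCCCC(CC)C(=O)Nc1c(OC)cc(OC)cc1OC`, 52 nM

In an assay on microsomes from intestine for inhibition of acyl-CoA:cholesterol acyltransferase (Oryctolagus cuniculus) (a higher number here means a weaker inhibitor, a lower number a stronger inhibitor), compound 2 gives 190 nM, the highest of the three numbers; compound 3 sits nearest to it, and compound 1 furthest. For the measured compounds named here, the only single-point step among the measured compounds is a 3.7-fold lower number from compound 2 to compound 3 (0.56 log units; beyond the scatter), which concerns branching next to the carbonyl rather than the far end of the chain. Compound 4, `CCCCCCCCCCCCCCC(=O)Nc1c(OC)cc(OC)cc1OC`, differs from compound 2 by methyl in place of hydrogen on a saturated chain carbon, ten or more bonds along the chain from a carbonyl carbon. Going by the values given here, no measured pair bears directly on a change of this kind, so the measured steps offer no guide on its direction. On that basis compound 4 is expected to show a 1.3-fold lower number from compound 2 to compound 4 (0.10 log units; within the scatter), a step not beyond the scatter in this assay. The estimate for compound 4 in this assay is therefore 150 nM, with a range from 60 nM to 400 nM.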

Compound 4, half-maximal inhibitory concentration: 65 nM
The estimate for compound 4 lay 2.3-fold (0.36 log units) above the measured number; low and high end bracket the measured number.
By their numbers in this assay, from the lowest: compounds 1, 3 and 4 (each within the scatter of the next); then compound 2.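

In this assay the added methyl gives a 2.9-fold lower number from compound 2 to compound 4 (0.47 log units; beyond the scatter) and so shows that the number responds to a change on a saturated chain carbon. For the compounds shown here, the only earlier step, a 3.7-fold lower number from compound 2 to compound 3 (0.56 log units; beyond the scatter) for ethyl in place of hydrogen on a chain carbon bound to the carbonyl carbon, said nothing about this distant position. Both single changes from compound 2 now lower the number, and no measurement at hand explains the effect of the methyl.

From the compounds shown here alone, whether a longer chain would lower the number further or reverse the trend remains open. So does whether a hydroxyl group or a carboxylic acid would be accepted at this position.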